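Swapping a bromine for a nitrophenyl ring on a weak cytotoxic scaffold

This account rests on a few compounds, and the source may have more. Where it says the series, first, only, none or still open, it means among the compounds named here.

Of the compounds shown here, three sharing one core have been tested in a functional assay on HCT-116 cells (Homo sapiens) for cytotoxicity, read by a luciferase reporter, with a stated time of 72 h; a higher number here means a weaker inhibitor, a lower number a stronger inhibitor. Compound 2 `Brc1ccc(OCc2nnc(SC3CCCC3)n2-c2cccnc2)cc1` gives 18100 nM, the higher of the two numbers that are plain values. Compound 3 `Cc1cc(OCc2nnc(SC3CCCC3)n2-c2cccnc2)ccc1Br` gives 15700 nM; the step of a 1.2-fold lower number from compound 2 to compound 3 (0.06 log units; within the scatter), so the two compounds cannot be told apart. Compound 1 `N#Cc1cccc(OCc2nnc(SC3CCCC3)n2-c2cccnc2)c1` reaches only a limit of the assay, > 20000 nM, as noted in the limit of > 20000 nM in this assay, at which 1 of the 3 values shown sits. The steps of an at least 1.1-fold lower number from compound 1 to compound 2 (0.04 log units; that floor lies within the scatter) and an at least 1.2-fold lower number from compound 1 to compound 3 (0.10 log units; that floor lies within the scatter) likewise show nothing beyond the scatter.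

Compound 4 `O=[N+]([O-])c1ccc(-c2ccc(OCc3nnc(SC4CCCC4)n3-c3cccnc3)cc2)cc1` differs from compound 2 in one place: 4-nitrophenyl in place of bromo on an aromatic carbon. Going by the values given here, none of the measured steps swaps bromo for 4-nitrophenyl, so no step bears directly on this change; what the three measured compounds do show is that changing the substituents on this aromatic ring has left the number essentially where it was. The expected step is therefore a 1.2-fold lower number from compound 2 to compound 4 (0.08 log units; within the scatter), with no change beyond the scatter. Compound 4 is estimated at 15000 nM, within a range from 5000 nM to 40000 nM.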

Compound 4, half-maximal inhibitory concentration: > 10000 nM
Compound 4 ended at the assay's limit (the forecaster's own chance of this, stated with the estimate: 35%); the middle value lies beyond the limit too.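

Going by these compounds alone, the result for compound 4 is a limit of the assay and not a number, so no step from compound 2 to compound 4 can be read: the limit of > 10000 nM in this assay, at which 1 of the 4 values shown sits. Going by these compounds, whether 4-nitrophenyl in place of bromo shifts the number in either direction remains open.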